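This account rests on a few compounds, and the source may have more. Where it says the series, first, only, none or still open, it means among the compounds named here.

In a functional assay on NCI-H460 cells (Homo sapiens) for cytotoxicity, read by MTT assay, with a stated time of 68 h (a higher number here means a weaker inhibitor, a lower number a stronger inhibitor), compound 1 `O=C(Nc1cccc(-c2ccc(-c3ccccc3)cc2)c1)C(Cl)Cl` gives 10900 nM, and compound 2 `O=C(Nc1cccc(-c2ccc(C(F)(F)F)cc2)c1)C(Cl)Cl` gives 33600 nM. For the measured compounds named here, compound 2 therefore has the higher of the two numbers so far, which makes it the weaker inhibitor of this pair. Compound 3 `O=C(Nc1cccc(-c2ccc(Cl)cc2)c1)C(Cl)Cl` has chloro in place of trifluoromethyl on an aromatic carbon. Going by the values given here, only one measured step bears on this change: a 3.1-fold higher number from compound 1 to compound 2 (0.49 log units; beyond the scatter). That modest step replaced phenyl with trifluoromethyl, whereas no ring leaves or enters on the way to compound 3. It is a weak guide, but a step no larger than that one is expected in this assay, possibly a slight move towards a lower number and possibly nothing beyond the scatter. The expected change is a 1.3-fold lower number from compound 2 to compound 3 (0.11 log units; within the scatter). The estimate for compound 3 is 26000 nM, within a range of 11000 nM to 55000 nM.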

Compound 3, half-maximal inhibitory concentration: > 50000 nM
Compound 3: a limit, no number; the forecaster's own chance of this, stated with the estimate: 5%; at least 1.9-fold (0.28 log units) between middle value and limit.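

Compound 3 gives no number, only a limit: the limit of > 50000 nM in this assay, at which 1 of the 3 values shown sits. Set against phenyl, chloro at this position, para to a large group, clearly gives a weaker result in this assay, with an at least 4.5-fold higher number from compound 1 to compound 3 (0.66 log units; beyond the scatter), so both groups without a ring tested here, trifluoromethyl and chloro, now sit on the weaker side of phenyl. Set against trifluoromethyl, the result is less firm, with an at least 1.4-fold higher number from compound 2 to compound 3 (0.17 log units; that floor lies within the scatter), so the swap of these two groups cannot be said to change the result by more than ordinary scatter.

As far as these compounds go, whether an amine, a carboxylic acid or a longer alkyl chain at this position would match phenyl remains open. The true value of compound 3 also remains open, as does any cause for these steps.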